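Working notes: compound 3 in the antiproliferative series

The compounds below may be only part of what the source reports. "The series", "measured", "known", "first", "only" and "open" are said of these compounds alone.

compound 1 `CCCN1CCN(c2ccc(S(=O)(=O)Oc3ccccc3CC)cc2)C1=O`: > 50000 nM in a functional assay on M21 cells (Homo sapiens) for antiproliferative activity, read by sulforhodamine B assay, with a stated time of 48 h (a lower number here means a stronger inhibitor, a higher number a weaker inhibitor), a limit of the assay
compound 2 `CCCN1CCN(c2ccc(S(=O)(=O)Oc3cccc(OC)c3)cc2)C1=O`: 10000 nM

Within the data shown here, compound 2 holds the only number in this assay, the other value shown, for compound 1, being a limit (the limit of > 50000 nM in this assay, at which 1 of the 2 values shown sits). Compound 3 `CCCN1CCN(c2ccc(S(=O)(=O)Oc3ccc(Cl)cc3)cc2)C1=O` differs from compound 2 by 4-chlorophenyl in place of 3-methoxyphenyl on an oxygen. Among the measured compounds shown here, the one measured step, an at least 5.0-fold lower number from compound 1 to compound 2 (0.69 log units; beyond the scatter), concerns a different pair of groups on the same oxygen and so bears only loosely on this change, and no step compares a chlorine with a methoxy. Lacking a closer guide, no step beyond the scatter is expected, and compound 3 is estimated at 10000 nM, between 3000 nM and 40000 nM, which would be a step of no change at the digits printed from compound 2 to compound 3 (within the scatter).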

Compound 3, half-maximal inhibitory concentration: 34000 nM
Compound 3: the middle estimate sits 3.4-fold (0.53 log units) below what was measured; measured number inside the range.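

The change from 3-methoxyphenyl to 4-chlorophenyl on the oxygen bonded to the sulfonyl sulfur is not neutral in this assay: it gives a 3.4-fold higher number from compound 2 to compound 3 (0.53 log units; beyond the scatter). The comparison with 2-ethylphenyl is less informative, with an at least 1.4-fold lower number from compound 1 to compound 3 (0.16 log units; that floor lies within the scatter), so compound 3 is not separated from compound 1. The value for compound 1 is a limit, not a number: the limit of > 50000 nM in this assay, at which 1 of the 3 values shown sits.

On these data alone, it remains open whether the methoxy group or its place on the ring accounts for the step; 4-methoxyphenyl and 3-chlorophenyl would separate the two. The compounds shown also do not indicate how an amine or a carboxylic acid on this ring would read.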